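The source may report more compounds than this note shows. Statements on the series, on what has been measured and on what is new or still open speak of the compounds shown alone.

Measured so far in an ADME assay on Vero cells (Chlorocebus sabaeus) for cytotoxicity, read by neutral red uptake, tested at 394 ug/mL; a lower number here means a stronger effect, a higher number a weaker effect of the compound at the concentration tested:
compound 1, `O=C1CSC(c2ccc(Cl)cc2)N1CCN1CCCCC1`: 28%
compound 2, `O=C1CSC(c2c(Cl)cccc2Cl)N1CCN1CCCCC1`: 32%
compound 3, `O=C1CSC(c2ccccc2[N+](=O)[O-])N1CCN1CCCCC1`: 100%

Compound 1 gives the lowest of the three numbers in this assay. Compound 2 stands nearest to it, and the gap between compound 1 and compound 2 lies within the scatter, so the two are not distinguishable on these data. Compound 3 stands furthest away, and the gap between compound 1 and compound 3 lies beyond the scatter. Among the compounds with values here, three compounds are too few to read a pattern from; no step between measured compounds is set out here.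

Compound 4, `O=C1CSC(c2cccc(O)c2)N1CCN1CCCCC1`, has not yet been measured in this assay. It differs from compound 1 in one place: 3-hydroxyphenyl in place of 4-chlorophenyl on a saturated ring carbon. Within the data shown here, nothing among the measured compounds shows a change of this kind on the saturated ring carbon, so the direction of the step is open. The step from compound 1 to compound 4 is expected to be moderate and towards a higher number, with a wide range that includes no change beyond the scatter: a number 22 percentage points higher from compound 1 to compound 4 (beyond the scatter). Compound 4 is estimated at 50%, with a range from 22% to 90%.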

Compound 4, a percentage reported as activity, at one concentration (the size of the read-out at that concentration, not a potency): 100%
For compound 4 the middle estimate is 50 percentage points below the measured one; the whole stated range lies below it.
By their numbers in this assay, from the lowest: compounds 1 and 2 (each within the scatter of the next); then compounds 3 and 4 (each within the scatter of the next).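

In this assay, 3-hydroxyphenyl in place of 4-chlorophenyl on a saturated ring carbon gives a number 72 percentage points higher from compound 1 to compound 4 (beyond the scatter), so a change to this one group, with the rest of the core of compound 1 kept, is enough to move the read-out by a large step. Across the four compounds, the two with chlorine on the phenyl ring, compound 1 at 28% and compound 2 at 32%, give the low numbers, while the two without it, compound 3 at 100% and compound 4 at 100%, give the high numbers; none of the four goes against this grouping, though four compounds are a narrow base for it. No measurement on hand accounts for the step, and its cause remains unassigned.

This step removes the chlorine, adds the hydroxyl and moves the substituent on the phenyl ring all at once, so the share of each in the result cannot be separated. Unsubstituted phenyl, 3-chlorophenyl and 4-hydroxyphenyl at the same carbon would divide the step into these parts, and an amine or a carboxylic acid on the phenyl ring would test whether the high numbers extend to other groups.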